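A few compounds are considered here, and "the series" means these few. Any claim that something is new, unique, unknown or untested is made for them only; others in the source may bear on it.

Three compounds share one core and differ only in the group attached to an aromatic carbon. Compound 1 `CC(C(=O)NCc1ccc(C(F)(F)F)nc1-c1ccc(Cl)cc1)c1ccc(NS(C)(=O)=O)c(F)c1` is the reference point, and in an assay on CHO cells for antagonist activity at transient receptor potential cation channel subfamily V member 1 (Homo sapiens), read by FLIPR (on this read-out lower numbers stand for stronger inhibition and higher numbers for weaker inhibition), compound 1 gives 0.7 nM. Compound 2 `CC(C(=O)NCc1ccc(C(F)(F)F)nc1-c1ccc(N(C)C)cc1)c1ccc(NS(C)(=O)=O)c(F)c1` carries dimethylamino in place of chloro on an aromatic carbon, and in this assay compound 2 gives 3.2 nM. Compound 3 `CC(C(=O)NCc1ccc(C(F)(F)F)nc1-c1ccc2cc[nH]c2c1)c1ccc(NS(C)(=O)=O)c(F)c1` carries 1H-indol-6-yl in place of 4-chlorophenyl on an aromatic carbon, and in this assay compound 3 gives 20.3 nM. Among these three numbers compound 2 stands second highest: the step of a 4.6-fold higher number from compound 1 to compound 2 (0.66 log units; beyond the scatter) separates it from its nearest neighbour, and the step of a 6.3-fold higher number from compound 2 to compound 3 (0.80 log units; beyond the scatter) from its furthest.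

Compound 4 `CC(C(=O)NCc1ccc(C(F)(F)F)nc1CCc1ccccc1)c1ccc(NS(C)(=O)=O)c(F)c1` is the next case. Its change from compound 2 is phenethyl in place of 4-(dimethylamino)phenyl on an aromatic carbon. The measured steps at this same aromatic carbon bear on it: a 4.6-fold higher number from compound 1 to compound 2 (0.66 log units; beyond the scatter) and a 6.3-fold higher number from compound 2 to compound 3 (0.80 log units; beyond the scatter) were each modest rises, while a 29-fold higher number from compound 1 to compound 3 (1.46 log units; beyond the scatter) shows how large a change at this place can become. Among the measured compounds shown here, a phenethyl group has not yet appeared in the set, so no step of exactly this kind exists. On the basis of the measured steps, a modest rise in this assay is expected. For compound 4 the estimate is 10 nM, with a range from 3 nM to 40 nM. That estimate corresponds to an expected step of a 3.1-fold higher number from compound 2 to compound 4 (0.49 log units; beyond the scatter).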

Compound 4, inhibition constant: 1.4 nM
Compound 4: the middle estimate sits 7.1-fold (0.85 log units) above what was measured, and the stated range ends above it.
By their numbers in this assay, from the lowest: compounds 1 and 4 (each within the scatter of the next); then compound 2; then compound 3.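

The position next to the ring nitrogen does not need an aryl group bonded directly to the aromatic carbon: in this assay, phenethyl, which holds its phenyl ring on a chain, reads on a par with 4-chlorophenyl (a 2.0-fold higher number from compound 1 to compound 4 (0.30 log units; within the scatter)). Phenethyl also reads better than the two nitrogen-bearing groups, with a modest gain over 4-(dimethylamino)phenyl (a 2.3-fold lower number from compound 2 to compound 4 (0.36 log units; beyond the scatter)) and a large one over 1H-indol-6-yl (a 15-fold lower number from compound 3 to compound 4 (1.16 log units; beyond the scatter)), so among these four compounds the two groups without nitrogen, in compound 1 and compound 4, both give lower numbers than the two with it, and no compound here goes against that order. Nothing available here explains these differences.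

The compounds shown leave open how the result depends on the chain, since a benzyl or a phenylpropyl group would show whether phenethyl's length matters, and a cyclohexylethyl group would show whether the chain's end needs to be an aromatic ring. They also leave open whether a chloro or dimethylamino group on the phenethyl ring would shift the number as it does on the directly attached phenyl ring.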